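Capping the chain nitrogen: what to expect for compound 4

The source may hold more compounds than are shown below. What is called first, only, known or untested is meant among the compounds shown, and "the series" means these compounds.

Three compounds have been measured in an assay on isolated protein for displacement of a labelled ligand from 5-hydroxytryptamine receptor 6 (Homo sapiens); a lower number here means a stronger inhibitor, a higher number a weaker inhibitor:
Compound 1, `CNS(=O)(=O)NC[C@@H]1CCCc2cc(S(=O)(=O)c3cccc(F)c3)ccc21`, gives 1 nM.
Compound 2, `O=C1CN(C[C@@H]2CCCc3cc(S(=O)(=O)c4cccc(F)c4)ccc32)CCN1`, gives 6.31 nM.
Compound 3, `NCC(=O)NC[C@@H]1CCCc2cc(S(=O)(=O)c3cccc(F)c3)ccc21`, gives 0.316 nM.

Compound 3 holds the lowest number of the three. Its nearest neighbour is compound 1, as seen in the step of a 3.2-fold lower number from compound 1 to compound 3 (0.50 log units; beyond the scatter); the furthest is compound 2, as seen in the step of a 20-fold lower number from compound 2 to compound 3 (1.30 log units; beyond the scatter). All three share the same core and differ only in the group hanging from the saturated chain carbon bound to the saturated ring carbon.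

Compound 4, `CC(=O)N(C)C[C@@H]1CCCc2cc(S(=O)(=O)c3cccc(F)c3)ccc21`, has not yet been measured. The change from compound 3 is acetyl(methyl)amino in place of ((aminomethyl)carbonyl)amino on a saturated chain carbon bound to a saturated ring carbon. Every measured exchange at this same position moved the number beyond the scatter: a 6.3-fold higher number from compound 1 to compound 2 (0.80 log units; beyond the scatter), a 3.2-fold lower number from compound 1 to compound 3 (0.50 log units; beyond the scatter) and a 20-fold lower number from compound 2 to compound 3 (1.30 log units; beyond the scatter). Among the compounds with values here, the group entering in compound 4 carries no hydrogen-bond donors and a single acceptor, which none of the measured groups at this position matches, so the direction must be judged from the spread already seen. A weaker result than compound 3 is expected, with a step beyond the scatter, estimated as a 32-fold higher number from compound 3 to compound 4 (1.50 log units; beyond the scatter). For compound 4 the expected value in this assay is 10 nM, with a range from 2 nM to 50 nM.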

Compound 4, inhibition constant: 1.59 nM
Beside the measured number, compound 4's estimate is 6.3-fold (0.80 log units) above it, outside the stated range (below it).
By their numbers in this assay, from the lowest: compound 3; then compounds 1 and 4 (each within the scatter of the next); then compound 2.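

Measured by this assay the group acetyl(methyl)amino shows that a low number at this place does not need hydrogen-bond donors in the group: it has none, yet the step of a 1.6-fold higher number from compound 1 to compound 4 (0.20 log units; within the scatter) leaves it level with the (methylsulfamoyl)amino of compound 1. The step of a 4.0-fold lower number from compound 2 to compound 4 (0.60 log units; beyond the scatter) puts it ahead of 3-oxopiperazin-1-yl, while the step of a 5.0-fold higher number from compound 3 to compound 4 (0.70 log units; beyond the scatter) shows that ((aminomethyl)carbonyl)amino, with its 2 hydrogen-bond donors, remains the better group at this position. Nothing available explains why these numbers move as they do.

The exchange from compound 3 to compound 4 alters two things at once, removing the aminomethyl part and adding a methyl on the amine nitrogen, so the compounds shown leave open which of the two accounts for the weaker number. A plain acetylamino group, which has the acetyl without that methyl, would separate the two effects, and a longer chain ending in the same amine would show whether the distance of that amine from the amide matters.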